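The source may hold more compounds than are shown below. What is called first, only, known or untested is meant among the compounds shown, and "the series" means these compounds.

Compound 1, `O=c1[nH]c(=O)n(CCC(CO)CO)cc1-c1ccco1`, gives in a functional assay on SW-620 cells (Homo sapiens) for antiproliferative activity, read by MTT assay, with a stated time of 72 h (a lower number here means a stronger inhibitor, a higher number a weaker inhibitor), only the limit > 100000 nM.
Compound 2, `O=c1[nH]c(=O)n(CCC(CO)CO)cc1-c1cccs1`, gives in this assay only the limit > 100000 nM.
Compound 3, `CC(=O)OCC(CCn1cc(C#Cc2ccc(Br)cc2)c(=O)n(C(=O)c2ccccc2)c1=O)COC(C)=O`, gives in this assay only the limit > 100000 nM.

Compound 3 therefore stands nowhere on a scale of numbers in this assay: its result is a limit, and the same holds for the other two values shown, so that (the limit of > 100000 nM in this assay, at which 3 of the 3 values shown sit). Among the measured compounds shown here, the one change that can be compared among the measured compounds, thiophen-2-yl in place of furan-2-yl on an aromatic carbon, gives a step that the two limits leave unreadable from compound 1 to compound 2, and nothing about its size can be read.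

Compound 4, `CC(=O)OCC(CCn1cc(C#CCc2ccccc2)c(=O)n(C(=O)c2ccccc2)c1=O)COC(C)=O`, is reached from compound 3 by benzyl in place of 4-bromophenyl on a triple-bonded carbon. For the measured compounds named here, no measured step touches this part of the molecule, and the one step that was measured is itself unreadable. There is thus no ground in the data to expect compound 4 to move off the limit, and it is expected to sit where compound 3 sits. The step expected from compound 3 to compound 4 in this assay is a step that the limit leaves unreadable from compound 3 to compound 4, with no change beyond the scatter anticipated. Compound 4 is accordingly estimated at 150000 nM, with a range from 50000 nM to 600000 nM.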

Compound 4, half-maximal inhibitory concentration: 36400 nM
Estimate against measurement, compound 4: 4.1-fold (0.61 log units) above; measured number outside the range, below it.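

In this assay, among the compounds shown here, the group on the triple-bonded carbon turns out to matter: benzyl in place of 4-bromophenyl gives an at least 2.7-fold lower number from compound 3 to compound 4 (0.43 log units; beyond the scatter), the first step in this set that can be read, and its full size stays unknown since one end of it is a limit. The two groups hold the same count of heavy atoms and each carries one six-membered aromatic ring of carbon only, so the step appears with those counts unchanged; what changes is the loss of bromine and the way the ring is joined, as the reading of 2-(4-bromophenyl)ethynyl to 3-phenylprop-1-yn-1-yl shows. For the compounds shown here, compound 4 is the only compound here that gives a number rather than a limit: the limit of > 100000 nM in this assay, at which 3 of the 4 values shown sit.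

The compounds shown do not separate the loss of bromine from the altered link to the ring, and a plain phenyl on the triple-bonded carbon would be needed to tell these apart. They also leave open whether a longer chain between the triple bond and the ring, or an amine on that ring, would lower the number further.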